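Moving a methoxy group around the anilino ring

This account rests on a few compounds, and the source may have more. Where it says the series, first, only, none or still open, it means among the compounds named here.

Of the compounds shown here, three of one shared core have been measured in a functional assay on MDA-MB-231 cells (Homo sapiens) for antiproliferative activity, read by MTT assay, with a stated time of 48 h; on this read-out lower numbers stand for stronger inhibition and higher numbers for weaker inhibition. Compound 1 `COC(=O)CN(C)c1nc(Nc2cccc(OC)c2)ncc1[N+](=O)[O-]` gives 58000 nM. Compound 2 `CCOC(=O)CNc1nc(Nc2ccc(Cl)cc2)ncc1[N+](=O)[O-]` gives 55500 nM. Compound 3 `CCOC(=O)CNc1nc(Nc2ccc(OC)cc2)ncc1[N+](=O)[O-]` gives 32600 nM, and all three numbers sit within the usual scatter of one another, so none of them can be set apart from the rest in this assay.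

Compound 4 `CCOC(=O)CNc1nc(Nc2cccc(OC)c2)ncc1[N+](=O)[O-]` differs from compound 3 in one place: 3-methoxyphenyl in place of 4-methoxyphenyl on a nitrogen on an aromatic ring, with the group on a nitrogen on an aromatic ring whose other neighbour is an aromatic carbon. For the measured compounds named here, only one measured step stands nearby, a 1.7-fold lower number from compound 2 to compound 3 (0.23 log units; within the scatter), and it swaps the substituent rather than its position, so it does not speak directly to this change. Compound 1 carries the 3-methoxyphenyl group but also differs elsewhere, so it offers only a loose hint. With nothing beyond the scatter to lean on, the expected step is a 1.3-fold higher number from compound 3 to compound 4 (0.11 log units; within the scatter), and compound 4 is estimated at 42000 nM, between 15000 nM and 110000 nM.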

Compound 4, half-maximal inhibitory concentration: 31300 nM
Beside the measured number, compound 4's estimate is 1.3-fold (0.13 log units) above it, within the range that was stated.
By their numbers in this assay, from the lowest: compounds 4, 3, 2 and 1 (each within the scatter of the next).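

In this assay, for the compounds shown here, moving the methoxy group gives a 1.0-fold lower number from compound 3 to compound 4 (0.02 log units; within the scatter), so on this nitrogen 3-methoxyphenyl and 4-methoxyphenyl cannot be told apart, a direct comparison of position that the earlier compounds did not offer. Placing 3-methoxyphenyl where 4-chlorophenyl stood gives a 1.8-fold lower number from compound 2 to compound 4 (0.25 log units; within the scatter), and ((ethoxycarbonyl)methyl)amino in place of ((methoxycarbonyl)methyl)(methyl)amino on an aromatic carbon gives a 1.9-fold lower number from compound 1 to compound 4 (0.27 log units; within the scatter), so none of the three new steps lies beyond the scatter. No evidence is available to explain this flat picture.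

As far as these compounds go, it remains open whether a carboxylic acid in place of the ethyl ester, or an amine on the anilino ring, would give a step beyond the scatter. The same question applies to a longer chain in place of the ethyl group of the ester.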